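The compounds below may be only part of what the source reports. "The series", "measured", "known", "first", "only" and "open" are said of these compounds alone.

In a functional assay on the whole organism (strain Wistar) for inhibition, with Rattus norvegicus as the target, read by paw edema, with a stated time of 3 h, at a dose of 10 mg/kg by the intraperitoneal route (on this read-out higher numbers stand for more inhibition at the one dose given (going by the name of the read-out) and lower numbers for less inhibition), compound 1 `O=C(N/N=C/c1ccccc1)c1cccnc1Nc1cccc(C(F)(F)F)c1` gives 21.2%, compound 2 `O=C(N/N=C/c1cccc(Cl)c1)c1cccnc1Nc1cccc(C(F)(F)F)c1` gives 55.2%, and compound 3 `O=C(N/N=C/c1ccc(Cl)cc1)c1cccnc1Nc1cccc(C(F)(F)F)c1` gives 48.5%. Compound 3 thus stands second highest of the three numbers, separated from compound 2 by a number 6.7 percentage points lower from compound 2 to compound 3 (within the scatter) and from compound 1 by a number 27.3 percentage points higher from compound 1 to compound 3 (beyond the scatter). Compound 4 `O=C(N/N=C/c1ccc(O)cc1)c1cccnc1Nc1cccc(C(F)(F)F)c1` differs from compound 3 by hydroxy in place of chloro on an aromatic carbon. Among the measured compounds shown here, no measured step swaps chloro for hydroxy; the nearest guide is a number 27.3 percentage points higher from compound 1 to compound 3 (beyond the scatter), which shows what the chloro added over hydrogen at this position. Taking that chloro away may give back part of that gain, and hydroxy has no precedent here, so a downward step is expected, a number 13.5 percentage points lower from compound 3 to compound 4 (beyond the scatter). Compound 4 is therefore estimated at 35%, within a range from 15% to 58%.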

Compound 4, a percentage reported as inhibition, in the whole organism at one dose (the size of the read-out at that dose, not a potency): 59.5%
Compound 4: the middle estimate sits 24.5 percentage points below what was measured; the whole stated range lies below it.
By their numbers in this assay, from the lowest: compound 1; then compounds 3, 2 and 4 (each within the scatter of the next, the first and the last beyond it).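

In this assay, swapping chloro for hydroxy on this aromatic carbon does not give back the gain over hydrogen (a number 11 percentage points higher from compound 3 to compound 4 (beyond the scatter)), and hydroxy also stands well clear of the unsubstituted ring (a number 38.3 percentage points higher from compound 1 to compound 4 (beyond the scatter)). The lift over hydrogen at this position therefore does not depend on chlorine, and 4-hydroxyphenyl cannot be told apart from 3-chlorophenyl (a number 4.3 percentage points higher from compound 2 to compound 4 (within the scatter)). No measurement here explains why the two groups behave this way. From the compounds shown here alone, whether a methoxy group or an amine on this carbon would keep the gain remains open, as does the result for 3-hydroxyphenyl.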